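The source may hold more compounds than are shown below. What is called first, only, known or untested is meant among the compounds shown, and "the series" means these compounds.

Compound 1 `CCCCN(c1nc2ccccc2o1)[C@H](C)c1ccc(-c2ccccc2-c2nnn[nH]2)cc1` is the parent of this small series. In an ADME assay on the whole organism (Macaca fascicularis) for pharmacokinetics, read by LC-MS, using cassette dosing, at a dose of 1 mg/kg by the oral route (on this read-out higher numbers stand for higher exposure at the dose given and lower numbers for lower exposure), compound 1 gives 44.3 ng.h/mL. Compound 2 `CCCCN(c1nc2c(CO)cccc2o1)[C@H](C)c1ccc(-c2ccccc2-c2nnn[nH]2)cc1` carries a hydroxymethyl group where compound 1 carries hydrogen, and in this assay compound 2 gives 20 ng.h/mL. Among the measured compounds shown here, the step of a 2.2-fold lower number from compound 1 to compound 2 (0.35 log units; beyond the scatter) is the only measured step in the set, and it leaves compound 2 with the lower of the two numbers, compound 1 standing above it by that step.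

Compound 3 `CCCCN(c1nc2c(C(=O)NS(C)(=O)=O)cccc2o1)[C@H](C)c1ccc(-c2ccccc2-c2nnn[nH]2)cc1` is reached from compound 2 by a change at the same aromatic carbon: (methylsulfonyl)carbamoyl in place of hydroxymethyl on an aromatic carbon. For the measured compounds named here, no measured step exchanges one substituent for another at this carbon; the single step from compound 1 to compound 2 only shows that introducing a group there lowered exposure modestly. On that slender basis a further modest drop, or no change beyond the scatter, is the expectation, with wide uncertainty. Compound 3 is therefore expected to give about 14 ng.h/mL, with a likely range from 4 ng.h/mL to 45 ng.h/mL. This estimate corresponds to the expected step of a 1.4-fold lower number from compound 2 to compound 3 (0.15 log units; within the scatter).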

Compound 3, area under the concentration-time curve: 22.2 ng.h/mL
Estimate against measurement, compound 3: 1.6-fold (0.20 log units) below; the range from low to high includes it.
By their numbers in this assay, from the lowest: compounds 2, 3 and 1 (each within the scatter of the next, the first and the last beyond it).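

At this aromatic carbon, ortho to a fused ring, (methylsulfonyl)carbamoyl in place of hydroxymethyl brings more heavy atoms and more hydrogen-bond acceptors, yet this assay records only a 1.1-fold higher number from compound 2 to compound 3 (0.05 log units; within the scatter). Among the compounds shown here, the two groups therefore cannot be told apart on this read-out, which the earlier pair alone could not show, since it held only one group at this carbon. Against hydrogen, the new group gives a 2.0-fold lower number from compound 1 to compound 3 (0.30 log units; within the scatter), whereas hydroxymethyl gave a 2.2-fold lower number from compound 1 to compound 2 (0.35 log units; beyond the scatter), so only the hydroxymethyl step lies beyond the scatter, and the gap between these two steps is no more than the small step between compound 2 and compound 3. Nothing available here explains why exposure responds in this way.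

The compounds shown leave open whether a carboxylic acid, an amine or a longer chain at this carbon would give a number close to these or one clearly apart from them. They also leave open whether hydroxymethyl or (methylsulfonyl)carbamoyl would behave the same way on another carbon of this six-membered ring.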